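Methoxy in Place of Chloro: What to Expect for Compound 4

A few compounds are considered here, and "the series" means these few. Any claim that something is new, unique, unknown or untested is made for them only; others in the source may bear on it.

Measured compounds:
compound 1 `Cc1cc2cc(NS(=O)(=O)c3cc(C(=O)NO)ccc3Cl)ccc2n(C)c1=O` gives 8%
compound 2 `COc1ccc(C(=O)NO)cc1NCc1ccc(OCCCCC(=O)Nc2ccc3c(c2)cc(C)c(=O)n3C)cc1` gives 0%
compound 3 `COC(=O)c1ccc(S(=O)(=O)Nc2ccc3c(c2)cc(C)c(=O)n3C)c(OC)c1` gives 85%

In a functional assay on THP-1 cells (Homo sapiens) for antiproliferative activity, tested at 20 uM (on this read-out lower numbers stand for a weaker effect and higher numbers for a stronger effect at the one concentration tested), compound 1 gives the second highest of the three numbers, 8%. Compound 2, with 0%, lies within the usual scatter of compound 1, so the two cannot be told apart. Compound 3, with 85%, stands well beyond that scatter above compound 1. The new compound 4 `COc1ccc(C(=O)NO)cc1S(=O)(=O)Nc1ccc2c(c1)cc(C)c(=O)n2C` keeps the core of compound 1 and changes a single place: methoxy in place of chloro on an aromatic carbon. For the measured compounds named here, compound 3 also carries a methoxy group, yet it differs from compound 4 elsewhere, so no measured pair gives the size of this change directly. An upward step of moderate size is expected in this assay, a number 22 percentage points higher from compound 1 to compound 4 (beyond the scatter), with wide uncertainty. Compound 4 is therefore estimated at 30%, between 5% and 75%.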

Compound 4, a percentage reported as inhibition, at one concentration (the size of the read-out at that concentration, not a potency): 32%
Beside the measured number, compound 4's estimate is 2 percentage points below it, and the stated range covers the measured number.
By their numbers in this assay, from the lowest: compounds 2 and 1 (each within the scatter of the next); then compound 4; then compound 3.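

Placing methoxy in place of chloro, para to a hydroxycarbamoyl group, gives the first direct reading of this change: in this assay there is a number 24 percentage points higher from compound 1 to compound 4 (beyond the scatter). This shows that the position responds to the group it carries, although the step is modest. No measurement here bears on the reason for this rise.

The compounds shown leave open how an amine, a fluoro group or a longer ethoxy chain would read at this position. They also leave open whether the same change would give a similar step on another compound.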